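Working notes: replacing the 4-(methylsulfonyl)piperazin-1-yl group

The compounds below may be only part of what the source reports. "The series", "measured", "known", "first", "only" and "open" are said of these compounds alone.

- compound 1 `COc1cc2nnc(C(N)=O)c(Nc3ccc(C)cc3F)c2cc1N1CCC(OC)CC1` gives 0.012
- compound 2 `COc1cc2nnc(C(N)=O)c(Nc3ccc(C)cc3F)c2cc1N1CCN(S(C)(=O)=O)CC1` gives 0.091

In an ADME assay on a cell-free system (plasma, Rattus norvegicus) for protein binding (on this read-out lower numbers stand for a smaller free fraction and higher numbers for a larger free fraction), compound 2 stands highest of the two measured compounds, at 0.091. Compound 3 `COc1cc2nnc(C(N)=O)c(Nc3ccc(C)cc3F)c2cc1N1C[C@@H](C)N[C@@H](C)C1` has not yet been measured. It carries 3,5-dimethylpiperazin-1-yl in place of 4-(methylsulfonyl)piperazin-1-yl on an aromatic carbon, ortho to a methoxy group: 3,5-dimethylpiperazin-1-yl in place of 4-(methylsulfonyl)piperazin-1-yl on an aromatic carbon.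

For the measured compounds named here, only one measured step bears on this change, made on the same aromatic carbon: a 7.6-fold higher number from compound 1 to compound 2 (0.88 log units; beyond the scatter). It lies beyond the scatter and shows that a swap here can move this assay appreciably. It does not involve the entering group, so the guidance is limited. A move towards a lower number is expected, smaller than that step, and the estimated step is a 2.3-fold lower number from compound 2 to compound 3 (0.36 log units; beyond the scatter). Compound 3 is expected at 0.04, within an estimated range of 0.015 to 0.1.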

Compound 3, unbound fraction: 0.013
Compound 3: the middle estimate sits 3.1-fold (0.49 log units) above what was measured; measured number below the stated range.
By their numbers in this assay, from the lowest: compounds 1 and 3 (each within the scatter of the next); then compound 2.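

In this assay the change to 3,5-dimethylpiperazin-1-yl gives a 7.0-fold lower number from compound 2 to compound 3 (0.85 log units; beyond the scatter) and so undoes, in size, the earlier 7.6-fold higher number from compound 1 to compound 2 (0.88 log units; beyond the scatter) on this same aromatic carbon. Set against the 4-methoxypiperidin-1-yl group, the same entering group gives a 1.1-fold higher number from compound 1 to compound 3 (0.03 log units; within the scatter) and stays within the scatter, so among these three compounds only compound 2, with its 4-(methylsulfonyl)piperazin-1-yl group, stands apart. Nothing on hand explains this separation.

The compounds shown leave open whether the higher number follows the methylsulfonyl group itself or the piperazine ring that carries it. A piperazine with no substituent, or one carrying an acetyl group, on this same aromatic carbon would bear on that question.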